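The source may hold more compounds than are shown below. What is called first, only, known or untested is meant among the compounds shown, and "the series" means these compounds.

Measured so far in a functional assay on HEK293 cells with D(4) dopamine receptor (Homo sapiens) as the target, read by FLIPR; a lower number here means that less compound is needed, a higher number that more compound is needed for the effect:
compound 2 `CO/N=C(\c1ccc(Cl)cc1)C(O)CN1CCN(c2ccccn2)CC1`, 46 nM
compound 1 `CO/N=C(/CCN1CCN(c2ccccn2)CC1)c1ccc(Cl)cc1`, 56.6 nM

Among the compounds with values here, compound 2 holds the lower of the two numbers, but its only neighbour, compound 1, sits within the scatter of it: the step of a 1.2-fold lower number from compound 1 to compound 2 (0.09 log units; within the scatter) is too small to rank the pair. Compound 3 `CO/N=C(\c1ccc(Cl)cc1)C(CN1CCN(c2ccccn2)CC1)OC` follows from compound 2 by methyl in place of hydrogen on an oxygen on a saturated carbon; read one bond further out, the hydroxy becomes a methoxy. Within the data shown here, no measured step alters a substituent on that oxygen. Among the measured compounds shown here, the one step that touches the same carbon, a 1.2-fold lower number from compound 1 to compound 2 (0.09 log units; within the scatter), introduced the hydroxy in the first place and moved the number only within the scatter. It bears on the present change only loosely, as adding a methyl to the oxygen is a different operation from the hydroxy entering, and it gives no indication of direction. With a single flat precedent, no step beyond the scatter is expected in this assay for compound 3. The estimated step for compound 3 is accordingly a 1.1-fold higher number from compound 2 to compound 3 (0.04 log units; within the scatter). On these data alone, the estimate for compound 3 in this assay is 50 nM, between 18 nM and 140 nM, the range kept wide as the change itself is untested.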

Compound 3, half-maximal effective concentration: 195 nM
The estimate for compound 3 lay 3.9-fold (0.59 log units) below the measured number; the measured number lies above the stated range.
By their numbers in this assay, from the lowest: compounds 2 and 1 (each within the scatter of the next); then compound 3.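

In this assay, within the data shown here, this saturated chain carbon is the first place where a change moves the number beyond the scatter: methyl in place of hydrogen on the oxygen gives a 4.2-fold higher number from compound 2 to compound 3 (0.63 log units; beyond the scatter) and so separates methoxy from hydroxy. Compared with the compound carrying only hydrogen on that carbon, methoxy gives a 3.4-fold higher number from compound 1 to compound 3 (0.54 log units; beyond the scatter) whereas hydroxy gave only a 1.2-fold lower number from compound 1 to compound 2 (0.09 log units; within the scatter) and the position therefore accepts one oxygen-bearing group with no readable shift but not the other. Nothing available here speaks to the reason for this difference.

On these data alone, it remains open whether the rise in this assay is specific to methyl or extends to other groups on that oxygen, such as ethyl, a longer chain or acetyl. Also open, as far as these compounds go, is how an amine or a fluorine on the same carbon would compare with hydrogen, hydroxy and methoxy.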